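Trading a trifluoromethyl aryl for a fluoro-methyl aryl amide

The compounds below may be only part of what the source reports. "The series", "measured", "known", "first", "only" and "open" are said of these compounds alone.

Measured compounds:
compound 1, `Cc1ccc(NC(=O)[C@H]2CN(C)C[C@@H]2c2ccc(/C=C/C(=O)Nc3ccccc3N)cc2)cc1`, 15 mL/min/kg
compound 2, `CN1C[C@H](C(=O)Nc2ccc(C(F)(F)F)cc2)[C@@H](c2ccc(/C=C/C(=O)Nc3ccccc3N)cc2)C1`, 6 mL/min/kg
compound 3, `CN1C[C@H](C(=O)Nc2ccccc2F)[C@@H](c2ccc(/C=C/C(=O)Nc3ccccc3N)cc2)C1`, 10 mL/min/kg

In an in vitro ADME assay on microsomes from liver (Homo sapiens) for pharmacokinetics, read by LC-MS, with a stated time of 10 min, tested at 1 uM (on this read-out lower numbers stand for slow clearance and higher numbers for fast clearance), compound 2 gives the lowest of the three numbers. Its nearest neighbour is compound 3, reached by a 1.7-fold higher number from compound 2 to compound 3 (0.22 log units; within the scatter). The furthest is compound 1: the step of a 2.5-fold lower number from compound 1 to compound 2 (0.40 log units; beyond the scatter) is the only one among the three that clears the scatter.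

Compound 4, `Cc1cc(NC(=O)[C@H]2CN(C)C[C@@H]2c2ccc(/C=C/C(=O)Nc3ccccc3N)cc2)ccc1F`, has not been measured. It differs from compound 2 in one place: 4-fluoro-3-methylphenyl in place of 4-(trifluoromethyl)phenyl on an amide-type nitrogen.

Among the compounds with values here, two measured steps bear on this. The step of a 2.5-fold lower number from compound 1 to compound 2 (0.40 log units; beyond the scatter) shows that replacing a methyl by a trifluoromethyl on the aromatic carbon went with a modest drop; compound 4 restores a methyl, so the reverse direction is the natural reading. The step of a 1.7-fold higher number from compound 2 to compound 3 (0.22 log units; within the scatter) shows that a different aryl amide with a single fluorine stayed within the scatter of compound 2. Taken together, a modest rise in this assay is expected for compound 4, landing between the numbers for compound 2 and compound 1, with the possibility that it stays within the scatter. The estimated step is a 1.7-fold higher number from compound 2 to compound 4 (0.22 log units; within the scatter). Compound 4 is therefore expected to give about 10 mL/min/kg, with a range from 5 mL/min/kg to 20 mL/min/kg.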

Compound 4, clearance: 15 mL/min/kg
Beside the measured number, compound 4's estimate is 1.5-fold (0.18 log units) below it; low and high end bracket the measured number.
By their numbers in this assay, from the lowest: compounds 2, 3, 1 and 4 (each within the scatter of the next, the first and the last beyond it).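

In this assay, the step of a 2.5-fold higher number from compound 2 to compound 4 (0.40 log units; beyond the scatter) clears the scatter, so the 4-(trifluoromethyl)phenyl of compound 2 now stands apart from a second methyl-bearing aryl group, not only from the 4-methylphenyl of compound 1. The step of no change at the digits printed from compound 1 to compound 4 (within the scatter) shows that, on this amide-type nitrogen, 4-fluoro-3-methylphenyl and 4-methylphenyl cannot be told apart on this read-out, so the fluorine that compound 4 carries does not bring its number towards that of compound 2. The step of a 1.5-fold higher number from compound 3 to compound 4 (0.18 log units; within the scatter) also stays within the scatter, so the separation of compound 2 holds against compounds 1 and 4 but not against compound 3, and the aryl groups shown do not fall into two clean sets.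

Nothing measured here explains why the number moves with these aryl groups. From the compounds shown here alone, it also remains open whether the separation of compound 2 belongs to the trifluoromethyl group specifically, or whether a nitrile, a chlorine or a methoxy group on the same aryl ring would give a similar number.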